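Solubility notes: aryl for benzyl on the core

The compounds below may be only part of what the source reports. "The series", "measured", "known", "first", "only" and "open" are said of these compounds alone.

Compound 2 `COc1cccc(CNCCCNc2ccnc3cc(Cc4ccccc4)ccc23)c1O` stands level with compound 1 `COc1ccc(F)cc1CNCCCNc1ccnc2cc(Cc3cc(C)cc(C)c3)ccc12` and compound 3 `COc1ccc(F)cc1CNCCCNc1ccnc2cc(Cc3ccccc3)ccc12` in a physicochemical assay for solubility, with a stated time of 18 h, at pH 7.4; a higher number here means a more soluble compound, a lower number a less soluble compound. In this assay compound 2 gives 4200 nM, compound 1 gives 4200 nM and compound 3 gives 4200 nM. The two measured steps both stay within the scatter: no change at the digits printed from compound 1 to compound 3 (within the scatter), and no change at the digits printed from compound 2 to compound 3 (within the scatter). Neither step moves the read-out at the digits shown.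

Compound 4 `COc1ccc(-c2ccc3c(NCCCNCc4cccc(OC)c4O)ccnc3c2)cc1` is the next member. It differs from compound 2 as follows: 4-methoxyphenyl in place of benzyl on an aromatic carbon. Among the compounds with values here, no measured step alters this place of the shared core; the step from compound 1 to compound 3 changed a group on a saturated chain carbon, and the step from compound 2 to compound 3 changed the group bound to the amine nitrogen. Both of those left this assay unchanged within the scatter, so the series has so far shown no sensitivity to replacement of one ring-bearing group by another, though neither step is a direct precedent for a change on an aromatic carbon of the core.

The expected step is a 1.1-fold lower number from compound 2 to compound 4 (0.02 log units; within the scatter), that is, no movement beyond the scatter. Compound 4 is estimated at 4000 nM, with a range from 1500 nM to 9000 nM.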

Compound 4, solubility: 32000 nM
Compound 4: middle estimate off by 8.0-fold (0.90 log units), on the low side; the measured number lies above the stated range.
By their numbers in this assay, from the lowest: compounds 1, 2 and 3 (each within the scatter of the next); then compound 4.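

Within the data shown here, on an aromatic carbon of the shared core, this assay responds to the group carried there: 4-methoxyphenyl in place of benzyl gives a 7.6-fold higher number from compound 2 to compound 4 (0.88 log units; beyond the scatter) and is the first step to pass beyond the scatter. The two earlier steps, made at other places, gave no such movement, so the flat read-out across compounds 1, 2 and 3 did not extend to this position. The change has two parts, however: the saturated carbon that links the ring to the core is gone, and a methoxy group enters, taking the group from 7 to 8 heavy atoms and from 0 hydrogen-bond acceptors to 1, while the single six-membered aromatic ring stays. Nothing at hand bears on why the number moves.

The compounds shown do not separate the loss of the linking carbon from the gain of the methoxy group; an unsubstituted phenyl on the same carbon would divide the two. Also open, going by these compounds, are how an amine or a carboxylic acid at this position would read, and whether the step holds with the 5-fluoro-2-methoxyphenyl group of compound 3 in place of the 2-hydroxy-3-methoxyphenyl group.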